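Swapping the para substituent: acetyl to chloro on the pendant phenyl

The source may report more compounds than this note shows. Statements on the series, on what has been measured and on what is new or still open speak of the compounds shown alone.

Measured compounds:
Compound 1, `Brc1cn2ccnc2c(-c2ccc3ncn(C4CCCCC4)c3c2)n1`: 6.6%
Compound 2, `c1cn2cc(-c3ccsc3)nc(-c3ccc4ncn(C5CCCCC5)c4c3)c2n1`: 1.51%
Compound 3, `CC(=O)c1ccc(-c2cn3ccnc3c(-c3ccc4ncn(C5CCCCC5)c4c3)n2)cc1`: 19.1%

All three compounds share the same core and differ only in the group on one aromatic carbon. In a functional assay on IGROV-1 cells (Homo sapiens) for inhibition, read by sulforhodamine B assay, with a stated time of 48 h, tested at 10 uM (a higher number here means more inhibition at the concentration tested (going by the name of the read-out), a lower number less inhibition), compound 3 gives the highest of the three numbers: the step of a number 12.5 percentage points higher from compound 1 to compound 3 (beyond the scatter) and the step of a number 17.6 percentage points higher from compound 2 to compound 3 (beyond the scatter) both lie beyond the scatter, while the step of a number 5.1 percentage points lower from compound 1 to compound 2 (within the scatter) lies within it.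

The unmeasured compound 4, `Clc1ccc(-c2cn3ccnc3c(-c3ccc4ncn(C5CCCCC5)c4c3)n2)cc1`, keeps the pendant phenyl of compound 3 and changes only its substituent:

chloro in place of acetyl on an aromatic carbon

Going by the values given here, no measured step covers chloro against acetyl on this phenyl ring. Among the compounds with values here, the two steps that bear on the question, a number 12.5 percentage points higher from compound 1 to compound 3 (beyond the scatter) and a number 17.6 percentage points higher from compound 2 to compound 3 (beyond the scatter), show only that the 4-acetylphenyl compound sits above a bromo and a thiophen-3-yl compound, which is not the change made here. Without a direct precedent, the expectation for this assay is a modest fall back toward the range of compound 1 and compound 2. Compound 4 is therefore estimated at 10%, with a range from 0% to 22%. The estimated step is a number 9.1 percentage points lower from compound 3 to compound 4 (within the scatter), expected to be at the edge of the scatter.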

Compound 4, a percentage reported as inhibition, at one concentration (the size of the read-out at that concentration, not a potency): 7.84%
For compound 4 the middle estimate is 2.2 percentage points above the measured one, and the stated range covers the measured number.
By their numbers in this assay, from the lowest: compounds 2, 1 and 4 (each within the scatter of the next); then compound 3.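

In this assay, the change on the pendant phenyl gives a number 11.3 percentage points lower from compound 3 to compound 4 (beyond the scatter), so the substituent on this ring, and not the ring alone, separates the two compounds. With chloro in place, the 4-chlorophenyl compound no longer stands apart from the other two groups at this position: the steps are a number 1.2 percentage points higher from compound 1 to compound 4 (within the scatter) and a number 6.3 percentage points higher from compound 2 to compound 4 (within the scatter), so among these four compounds only the 4-acetylphenyl group gives a higher number. Nothing shown here explains the difference between acetyl and chloro on this ring.

On these data alone, whether the higher number goes with the carbonyl of acetyl remains open, and a nitrile, an amide or a carboxylic acid at the same place could test this. The unsubstituted phenyl, which would show how much either substituent changes the number, is also left open.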